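Ester urea series: exchanging the terminal aryl group

The source may hold more compounds than are shown below. What is called first, only, known or untested is meant among the compounds shown, and "the series" means these compounds.

Measured so far:
compound 1 `O=C(Nc1ccc(-n2ccc3nc(C(=O)NCc4ccccc4)ccc32)cc1)Nc1ccc(Cl)c(C(F)(F)F)c1`: 1100 nM
compound 2 `COC(=O)c1ccc2c(ccn2-c2ccc(NC(=O)Nc3ccc(Cl)c(C(F)(F)F)c3)cc2)n1`: 3600 nM
compound 3 `NC(=O)c1ccc2c(ccn2-c2ccc(NC(=O)c3cccc(C(F)(F)F)c3)cc2)n1`: a limit, > 10000 nM

In a functional assay on A375P cells (Homo sapiens) for cytotoxicity, read by MTT assay (a lower number here means a stronger inhibitor, a higher number a weaker inhibitor), compound 2 gives 3600 nM, the highest of the two numbers shown; the nearest is compound 1 with 1100 nM, and the step of a 3.3-fold higher number from compound 1 to compound 2 (0.51 log units; beyond the scatter) is modest but beyond the scatter. For compound 3 only the limit > 10000 nM is recorded (the limit of > 10000 nM in this assay, at which 1 of the 3 values shown sits).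

Compound 4 `COC(=O)c1ccc2c(ccn2-c2ccc(NC(=O)Nc3cccc(Cl)c3Cl)cc2)n1` differs from compound 2 by 2,3-dichlorophenyl in place of 4-chloro-3-(trifluoromethyl)phenyl on an amide-type nitrogen. Going by the values given here, no measured step touches the aryl group on that amide-type nitrogen; the single step measured concerns the carbonyl substituent and cannot be carried over. In the absence of such evidence, compound 4 is expected to stay close to compound 2, within the scatter, a 1.3-fold higher number from compound 2 to compound 4 (0.10 log units; within the scatter), with a wide band. The estimate for compound 4 in this assay is 4500 nM, between 1500 nM and 15000 nM.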

Compound 4, half-maximal inhibitory concentration: 6400 nM
For compound 4 the middle estimate is 1.4-fold (0.15 log units) below the measured one; the measured number falls inside the stated range.
By their numbers in this assay, from the lowest: compound 1; then compounds 2 and 4 (each within the scatter of the next). At a limit, above all of these: compound 3.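

In this assay, going by these compounds alone, exchanging the terminal aryl group on the amide-type nitrogen gives a 1.8-fold higher number from compound 2 to compound 4 (0.25 log units; within the scatter), the first direct reading at this position. Within the ester ureas, 2,3-dichlorophenyl and 4-chloro-3-(trifluoromethyl)phenyl therefore cannot be told apart, even though the exchange removes the trifluoromethyl group. No evidence at hand bears on this result.

From the compounds shown here alone, it remains open whether this position accepts an unsubstituted phenyl or a pyridine ring. Going by these compounds, it is also open whether 2,3-dichlorophenyl would pair with the benzylamide of compound 1, or with a carboxylic acid on the carbonyl carbon.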